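The source may report more compounds than this note shows. Statements on the series, on what has been measured and on what is new or still open speak of the compounds shown alone.

Among the compounds with values here, only two compounds built on the same core have been measured so far. In a functional assay on L1210 cells (Mus musculus) for inhibition (on this read-out higher numbers stand for weaker inhibition and lower numbers for stronger inhibition), compound 1 `C#CCN(Cc1ccc2nc(C)nc(O)c2c1)c1ccccc1` gives > 6500 nM, which is a limit of the assay and not a number. Within the data shown here, compound 2 `C#CCN(Cc1ccc2nc(C)nc(O)c2c1)c1cccc(CC)c1` gives 5000 nM, the only true number available at this stage. It differs from compound 1 by having ethyl in place of hydrogen on an aromatic carbon. That single measured step, an at least 1.3-fold lower number from compound 1 to compound 2 (0.11 log units; that floor lies within the scatter), has no firm size, and its floor lies within the scatter.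

Compound 3 `C#CCN(Cc1ccc2nc(C)nc(O)c2c1)c1cccc(C(C)O)c1` changes the ethyl group of compound 2: hydroxy in place of hydrogen on a saturated chain carbon bound to an aromatic carbon and a saturated chain carbon. Hydroxy takes the place of hydrogen on a saturated chain carbon bound to an aromatic carbon and a saturated chain carbon, so ethyl becomes 1-hydroxyethyl. Among the measured compounds shown here, no measured step involves a hydroxy group, so the earlier step gives only weak guidance on size and none on direction. No change beyond the scatter is therefore expected in this assay. The expected step is a 1.3-fold lower number from compound 2 to compound 3 (0.10 log units; within the scatter), and it is only an estimate. The estimated value for compound 3 is 4000 nM, with an expected range from 1200 nM to 12000 nM.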

Compound 3, half-maximal inhibitory concentration: > 49000 nM
Compound 3 ended at the assay's limit (the forecaster's own chance of this, stated with the estimate: 25%); middle value at least 12-fold (1.08 log units) from the limit.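

In this assay, placing hydroxy on the saturated chain carbon bound to an aromatic carbon and a saturated chain carbon, which turns ethyl into 1-hydroxyethyl, gives an at least 9.8-fold higher number from compound 2 to compound 3 (0.99 log units; beyond the scatter). Within the data shown here, this is the first step that is clearly beyond the scatter, so a change of a single heavy atom at this place can weaken inhibition markedly, something the earlier step, with no firm size, could not show. The real size of this step remains unknown, and the figure given is only a floor, since compound 3 sits at a limit of the assay and not at a number: the limit of > 49000 nM in this assay, at which 1 of the 3 values shown sits.

As far as these compounds go, the step from compound 1 to compound 3 cannot be read, so how 1-hydroxyethyl compares with plain hydrogen on the aromatic carbon stays open. From the compounds shown here alone, it is also open whether the weaker inhibition is specific to hydroxy, or whether a methoxy group, an amine or a carboxylic acid on the same chain carbon would give a similar result.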